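The compounds below may be only part of what the source reports. "The series", "measured", "known", "first", "only" and "open" are said of these compounds alone.

compound 1 `CCCCc1cc2c(=O)c(CC)c[nH]c2cc1OCCOc1ccccc1`: 360 nM
compound 2 `COC(=O)c1c[nH]c2ccc(OCc3ccccc3)cc2c1=O`: 7590 nM
compound 3 `COC(=O)c1c[nH]c2cc(Oc3ccccc3)ccc2c1=O`: 9120 nM

All three values come from an ADME assay on J774 cells (Mus musculus) for cytotoxicity; a lower number here means that less compound is needed, a higher number that more compound is needed for the effect. Compound 1 has the lowest number of the set, and its gap to each of compound 2 and compound 3 lies beyond the scatter. Compound 2 and compound 3 lie within the scatter of each other.

The next compound to be measured is compound 4 `CCCCc1cc2c(=O)c(C(=O)NC)c[nH]c2cc1OCCOc1ccccc1`, which differs from compound 1 at a single place: methylcarbamoyl in place of ethyl on an aromatic carbon. Among the measured compounds shown here, no measured pair isolates this change, so its size in this assay cannot be read directly. For the measured compounds named here, the only indirect guide is weak. Compound 2 at 7590 nM and compound 3 at 9120 nM also lack the ethyl group, but they differ from compound 1 in other places as well. On that limited basis, a moderate step toward a higher number is expected, probably beyond the scatter and smaller than the gaps separating compound 1 from those two compounds. The estimated change is a 4.2-fold higher number from compound 1 to compound 4 (0.62 log units; beyond the scatter). For compound 4 the expected value is 1500 nM, with an estimated range of 450 nM to 6000 nM.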

Compound 4, half-maximal effective concentration: > 20000 nM
Compound 4: a limit, no number; the forecaster's own chance of this, stated with the estimate: 5%; middle value at least 13-fold (1.12 log units) from the limit.
By their numbers in this assay, from the lowest: compound 1; then compounds 2 and 3 (each within the scatter of the next). At a limit, above all of these: compound 4.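

In this assay, compound 4 gives > 20000 nM, which is a limit of the assay and not a number. Methylcarbamoyl in place of ethyl on this aromatic carbon, two atoms from the ring nitrogen, gives an at least 55-fold higher number from compound 1 to compound 4 (1.74 log units; beyond the scatter), the first step in the series that isolates a change at one place, as the earlier compounds offered no such pair. This position is therefore sensitive to the group it carries in this read-out, with the change to methylcarbamoyl moving the result beyond the scatter, though the full size of the step cannot be read from a value at the limit: the limit of > 20000 nM in this assay, at which 1 of the 4 values shown sits.

A single pair cannot show whether the step follows from the loss of ethyl or from the entry of methylcarbamoyl, and a longer chain such as propyl, a nitrile, a carboxylic acid or an unsubstituted carboxamide on the same carbon would begin to separate the two. On these data alone, whether methylcarbamoyl gives a step of similar size when the rest of compound 1 is changed also remains open, as does any value for compound 4 below the limit under other test conditions.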